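Phenethyl in place of 4-fluorophenyl on a shared core

The source may report more compounds than this note shows. Statements on the series, on what has been measured and on what is new or still open speak of the compounds shown alone.

Measured compounds:
- compound 1 `CCCc1n[nH]c2c(=O)n(NC(=O)c3ccncc3)c(-c3cccc(OC)c3)nc12`: 0.07%
- compound 2 `O=C(Nn1c(-c2cccc([N+](=O)[O-])c2)nc2c(-c3ccc(F)cc3)n[nH]c2c1=O)c1cccnc1`: 24.7%

Both were tested in a functional assay on HT-29 cells (Homo sapiens) for cytotoxicity, read by sulforhodamine B assay, with a stated time of 2 days, tested at 100 uM; on this read-out higher numbers stand for more inhibition at the one concentration tested (going by the name of the read-out) and lower numbers for less inhibition. Compound 1 gives 0.07%, and compound 2 gives 24.7%, the higher of the two numbers, with a gap to compound 1 that lies beyond the scatter. Going by the values given here, no pair of measured compounds differs in only one place, so no single change has yet been sized. Compound 3 `O=C(Nn1c(-c2cccc([N+](=O)[O-])c2)nc2c(CCc3ccccc3)n[nH]c2c1=O)c1cccnc1` is the untested analogue, differing from compound 2 by phenethyl in place of 4-fluorophenyl on an aromatic carbon. Among the compounds with values here, with no comparable step to draw on, the change from compound 2 is expected to move the number modestly downward, within the range of ordinary variation or a little beyond, as a number 9.7 percentage points lower from compound 2 to compound 3 (within the scatter). Compound 3 is estimated at 15%, between 0% and 40%.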

Compound 3, a percentage reported as inhibition, at one concentration (the size of the read-out at that concentration, not a potency): 20.1%
The estimate for compound 3 lay 5.1 percentage points below the measured number; the measured number falls inside the stated range.
By their numbers in this assay, from the lowest: compound 1; then compounds 3 and 2 (each within the scatter of the next).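

In this assay, phenethyl in place of 4-fluorophenyl on this aromatic carbon gives a number 4.6 percentage points lower from compound 2 to compound 3 (within the scatter). Removing the fluorine and adding a chain in one swap therefore leaves the read-out within ordinary scatter, so both groups are accommodated at this position on this shared core. Nothing available explains this outcome.

As far as these compounds go, whether a carboxylic acid or an amine at this position would give a similar number remains open. So does whether this swap would behave the same way with different groups elsewhere on the core.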